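Benzyl variation on the shared core: nitrophenyl analog

The source may report more compounds than this note shows. Statements on the series, on what has been measured and on what is new or still open speak of the compounds shown alone.

Compound 1 `Cc1cc(Nc2nn(Cc3cc(F)ccc3F)c(=O)c3ccccc23)n[nH]1` and compound 2 `Cc1cc(Nc2nn(Cc3ccncc3)c(=O)c3ccccc23)n[nH]1` share a core and differ only at the saturated chain carbon bound to an aromatic nitrogen. In a functional assay on MCF7 cells (Homo sapiens) for cytotoxicity (on this read-out higher numbers stand for weaker inhibition and lower numbers for stronger inhibition), compound 1 reaches only the limit > 30000 nM. In this assay compound 2 likewise gives only the limit > 30000 nM. The step that the two limits leave unreadable from compound 1 to compound 2 therefore cannot be read, as the limit of > 30000 nM in this assay, at which 2 of the 2 values shown sit, shows. Compound 3 `Cc1cc(Nc2nn(Cc3ccc([N+](=O)[O-])cc3)c(=O)c3ccccc23)n[nH]1` carries the change (4-nitrophenyl in place of pyridin-4-yl on a saturated chain carbon bound to an aromatic nitrogen). No readable measured step bears on it, so the expected step of a number no higher from compound 2 to compound 3 (the limit leaves the size open) is nothing beyond the scatter. Compound 3 is estimated at 30000 nM, between 8000 nM and 100000 nM, most probably again only a limit.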

Compound 3, half-maximal inhibitory concentration: > 30000 nM
Compound 3: no number, only a limit (the forecaster's own chance of this, stated with the estimate: 75%); the middle value lies on the limit itself.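

Compound 3 gives only a limit in this assay, so no step among compound 1, compound 2 and compound 3 can be read: the limit of > 30000 nM in this assay, at which 3 of the 3 values shown sit.

The compounds shown leave open whether any group at this place gives a measurable cytotoxic potency on the shared core.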